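The compounds below may be only part of what the source reports. "The series", "measured", "known", "first", "only" and "open" are said of these compounds alone.

Working notes on the series. Compound 1 `COc1cc2c(Oc3ccc(NC(=O)c4nn(-c5ccc(Cl)cc5)c(=O)cc4C)cc3F)ccnc2cc1OCCCN1CCCC1` is the reference point; in a functional assay on NCI-H460 cells (Homo sapiens) for inhibition, read by MTT assay, with a stated time of 72 h (a lower number here means a stronger inhibitor, a higher number a weaker inhibitor), compound 1 gives 360 nM. Compound 2 `COc1cc2c(Oc3ccc(NC(=O)c4nn(-c5ccc(Cl)cc5)c(=O)cc4C)cc3F)ccnc2cc1OCCCN1CCN(C)CC1` differs from compound 1 by one change, (4-methylpiperazin-1-yl in place of pyrrolidin-1-yl on a saturated chain carbon, three bonds along the chain from an oxygen on an aromatic ring), and in this assay compound 2 gives 440 nM, which is a 1.2-fold higher number from compound 1 to compound 2 (0.09 log units; within the scatter). Compound 3 `COc1cc2c(Oc3ccc(NC(=O)c4nn(-c5ccc(F)c(F)c5)c(=O)cc4C)cc3F)ccnc2cc1OCCCN1CCCC1` differs from compound 1 in the core, namely (3,4-difluorophenyl in place of 4-chlorophenyl on an aromatic nitrogen). In this assay compound 3 gives 170 nM, which is a 2.1-fold lower number from compound 1 to compound 3 (0.33 log units; beyond the scatter); its number is the lowest of the three measured, and its steps to compound 1 and to compound 2 are both beyond the scatter.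

Compound 4 `COc1cc2c(Oc3ccc(NC(=O)c4nn(-c5ccc(F)c(F)c5)c(=O)cc4C)cc3F)ccnc2cc1OCCCN1CCN(C)CC1` has not yet been measured. It differs from compound 3 by 4-methylpiperazin-1-yl in place of pyrrolidin-1-yl on a saturated chain carbon, three bonds along the chain from an oxygen on an aromatic ring, the same change as from compound 1 to compound 2; the place is described identically in both pairs, and the two cores differ only as set out for compound 1 and compound 3. Only one earlier case of this change is available, so the expectation is weakly founded. Among the compounds with values here, the step from compound 3 to compound 4 in this assay is expected to be a 1.2-fold higher number from compound 3 to compound 4 (0.07 log units; within the scatter), beside the measured 1.2-fold higher number from compound 1 to compound 2 (0.09 log units; within the scatter), because the one earlier instance gave a 1.2-fold higher number from compound 1 to compound 2 (0.09 log units; within the scatter). Compound 4 is therefore estimated at 200 nM in this assay. The expected range runs from 100 nM to 420 nM, kept wide since a single prior case cannot fix the size of the step.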

Compound 4, half-maximal inhibitory concentration: 190 nM
Compound 4: the middle estimate sits 1.1-fold (0.02 log units) above what was measured; measured number inside the range.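

In this assay, 4-methylpiperazin-1-yl in place of pyrrolidin-1-yl gives a 1.1-fold higher number from compound 3 to compound 4 (0.05 log units; within the scatter), and this side-chain change reads the same on both cores: the same change on two cores in this assay, a 1.2-fold higher number (0.09 log units; within the scatter) from compound 1 to compound 2 and a 1.1-fold higher number (0.05 log units; within the scatter) from compound 3 to compound 4, 1.1-fold (0.04 log units) apart, within the scatter of two such steps

The other change, 3,4-difluorophenyl in place of 4-chlorophenyl on an aromatic nitrogen, gives a 2.3-fold lower number from compound 2 to compound 4 (0.36 log units; beyond the scatter) with 4-methylpiperazin-1-yl in place, and it also reads the same with either side chain: the same change on two cores in this assay, a 2.1-fold lower number (0.33 log units; beyond the scatter) from compound 1 to compound 3 and a 2.3-fold lower number (0.36 log units; beyond the scatter) from compound 2 to compound 4, 1.1-fold (0.04 log units) apart, within the scatter of two such steps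

Across these four compounds, then, each change carries over with no visible dependence on the other, but this rests on only two pairs per change in a single cell assay, and it shows neither why the steps agree nor whether they would hold on any other core or in any other assay.

As far as these compounds go, whether the side-chain result extends to other amines in the same place, such as morpholin-4-yl or dimethylamino, or to a shorter chain such as 2-(pyrrolidin-1-yl)ethyl, remains open. Also open, from the compounds shown here alone, is whether other groups on the aromatic nitrogen, such as an unsubstituted phenyl or a 4-methoxyphenyl, would combine with these side chains in the same way.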